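This account rests on a few compounds, and the source may have more. Where it says the series, first, only, none or still open, it means among the compounds named here.

Measured compounds:
Compound 1 `COc1cc(NC(C)CCCNC(=O)Nc2cccc(Cl)c2)c2ncccc2c1` — 11000 nM
Compound 2 `COc1cc(NC(C)CCCNC(=O)Nc2ccc(Br)cc2)c2ncccc2c1` — 2600 nM
Compound 3 `COc1cc(NC(C)CCCNC(=O)Nc2ccc(F)cc2)c2ncccc2c1` — 26000 nM

In a functional assay on MCF7 cells (Homo sapiens) for inhibition, read by MTT assay, with a stated time of 72 h (on this read-out lower numbers stand for stronger inhibition and higher numbers for weaker inhibition), compound 3 gives the highest of the three numbers; the step of a 10-fold higher number from compound 2 to compound 3 (1.00 log units; beyond the scatter) is the largest gap, and a 2.4-fold higher number from compound 1 to compound 3 (0.37 log units; beyond the scatter) is smaller. Compound 4 `COc1cc(NC(C)CCCNC(=O)NNC(=O)Nc2ccc(O)cc2)c2ncccc2c1` is reached from compound 3 by ((4-hydroxyphenyl)carbamoyl)amino in place of 4-fluorophenyl on an amide-type nitrogen. The measured steps all swap one halogenated phenyl for another on the same nitrogen: a 4.2-fold lower number from compound 1 to compound 2 (0.63 log units; beyond the scatter), a 2.4-fold higher number from compound 1 to compound 3 (0.37 log units; beyond the scatter) and a 10-fold higher number from compound 2 to compound 3 (1.00 log units; beyond the scatter). None of them inserts a carbamoylamino linker or a hydroxyl, so they bear only loosely on this change. The expectation is therefore wide, centred near compound 3 with a possible modest move in either direction. Compound 4 is estimated at 15000 nM, ranging from 3000 nM to 60000 nM, meaning an expected step of a 1.7-fold lower number from compound 3 to compound 4 (0.24 log units; within the scatter).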

Compound 4, half-maximal inhibitory concentration: 2600 nM
The estimate for compound 4 lay 5.8-fold (0.76 log units) above the measured number; measured number below the stated range.
By their numbers in this assay, from the lowest: compounds 2 and 4 (each within the scatter of the next); then compound 1; then compound 3.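

In this assay the amide-type nitrogen accepts a larger group without a halogen: ((4-hydroxyphenyl)carbamoyl)amino gives a 10-fold lower number from compound 3 to compound 4 (1.00 log units; beyond the scatter) against 4-fluorophenyl and a 4.2-fold lower number from compound 1 to compound 4 (0.63 log units; beyond the scatter) against 3-chlorophenyl. Against 4-bromophenyl it gives no change at the digits printed from compound 2 to compound 4 (within the scatter) and so matches the lowest number in the set, which shows that a halogen on the phenyl is not required to reach it. No measurement here explains these steps.

As far as these compounds go, the carbamoylamino linker and the hydroxyl enter together, so their separate contributions remain open. From the compounds shown here alone, how a methoxy group or an amine would read in place of that hydroxyl also remains open.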